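Adding a substituted benzyl to a fluorinated ring nitrogen

A few compounds are considered here, and "the series" means these few. Any claim that something is new, unique, unknown or untested is made for them only; others in the source may bear on it.

Measured in a functional assay on Bel-7402 cells (Homo sapiens) for antiproliferative activity, read by MTT assay, with a stated time of 72 h; on this read-out lower numbers stand for stronger inhibition and higher numbers for weaker inhibition:
- compound 1 `C=C1C(=O)O[C@H]2[C@H]1CC/C(COC(=O)Cn1cc(F)c(=O)[nH]c1=O)=C\CC[C@@]1(C)O[C@@H]21`: > 20000 nM
- compound 2 `C=C1C(=O)O[C@H]2[C@H]1CC/C(COC(=O)CCC(=O)OCn1cc(F)c(=O)[nH]c1=O)=C\CC[C@@]1(C)O[C@@H]21`: > 20000 nM
- compound 3 `C=C1C(=O)O[C@H]2[C@H]1CC/C(COC(=O)CCC(=O)NCCCCCCNC(=O)Cn1cc(F)c(=O)n(Cc3ccccc3)c1=O)=C\CC[C@@]1(C)O[C@@H]21`: 18300 nM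

In this assay compound 1 gives > 20000 nM, which is a limit and not a number. Compound 2 gives > 20000 nM, also a limit. Going by the values given here, compound 3 gives the only numerical reading, 18300 nM.

Compound 4 `C=C1C(=O)O[C@H]2[C@H]1CC/C(COC(=O)Cn1cc(F)c(=O)n(Cc3ccc(C(F)(F)F)cc3)c1=O)=C\CC[C@@]1(C)O[C@@H]21` keeps the core of compound 1 and places 4-(trifluoromethyl)benzyl in place of hydrogen on an aromatic nitrogen. Among the compounds with values here, no measured pair isolates this change. The nearest guide is compound 3, which also carries a benzyl group on an aromatic nitrogen, although with a much longer chain, and gives 18300 nM. A modest shift toward stronger inhibition is therefore expected, and a reading still at the limit remains possible. The expected size of the change is an at least 2.0-fold lower number from compound 1 to compound 4 (0.30 log units; that floor lies within the scatter). For compound 4 the estimated value is 10000 nM, with an expected range from 3500 nM to 25000 nM.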

Compound 4, half-maximal inhibitory concentration: 2250 nM
Compound 4: the middle estimate sits 4.4-fold (0.65 log units) above what was measured; measured number outside the range, below it.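

In this assay, 4-(trifluoromethyl)benzyl in place of hydrogen on an aromatic nitrogen gives an at least 8.8-fold lower number from compound 1 to compound 4 (0.94 log units; beyond the scatter). The earlier compounds shown here offered no pair that isolated this position, and this step shows that the nitrogen can carry a group of 11 heavy atoms with stronger inhibition rather than a loss. The true size of the step stays unknown, and only its floor can be read, since compound 1 gives > 20000 nM, a limit of the assay and not a number: the limit of > 20000 nM in this assay, at which 2 of the 4 values shown sit.

As far as these compounds go, it remains open how much of the step belongs to the benzyl ring and how much to the trifluoromethyl group, and whether plain benzyl, 4-methoxybenzyl or a simple methyl on the same nitrogen would read alike. Also open, from the compounds shown here alone, is whether an amine or a carboxylic acid on the benzyl ring would keep the inhibition.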